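Swapping trifluoromethyl for an ester chain on compound 3

A few compounds are considered here, and "the series" means these few. Any claim that something is new, unique, unknown or untested is made for them only; others in the source may bear on it.

Compound 3 `COCCn1cc(C(=O)C(=O)Nc2ccc(C(F)(F)F)nc2)c2ccccc21` was tested in a functional assay on FaDu cells (Homo sapiens) for cytotoxicity, read by MTT assay, with a stated time of 72 h; a higher number here means that more compound is tolerated, a lower number that less compound is tolerated. In that test compound 3 gives only a limit, > 10000 nM. Compound 1 `CC(C)n1cc(C(=O)C(=O)Nc2ccc(C(F)(F)F)nc2)c2ccccc21` also gives only a limit, > 10000 nM. The step from compound 1 to compound 3 is a step that the two limits leave unreadable from compound 1 to compound 3, with both values sitting at the limit of > 10000 nM in this assay, at which 2 of the 3 values shown sit. Compound 2 `COc1ccc(NC(=O)C(=O)c2cn(CC(C)C)c3ccccc23)cn1`, which carries methoxy where the others carry trifluoromethyl and also differs on the aromatic nitrogen, gives 317 nM in this assay. Compound 4 `CCOC(=O)COc1ccc(NC(=O)C(=O)c2cn(CCOC)c3ccccc23)cn1` differs from compound 3 by (ethoxycarbonyl)methoxy in place of trifluoromethyl on an aromatic carbon. Going by the values given here, no measured step covers this change, so the expectation rests loosely on compound 2 and is wide. Compound 4 is estimated at 3000 nM, with a range from 400 nM to 20000 nM. This corresponds to an expected step of an at least 3.3-fold lower number from compound 3 to compound 4 (0.52 log units; beyond the scatter).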

Compound 4, concentration lethal to 50% of the cells: > 10000 nM
Compound 4 ended at the assay's limit; the forecaster's own chance of this, stated with the estimate: 45%; middle value at least 3.3-fold (0.52 log units) from the limit.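

Compound 3 and compound 4 both end at a limit in this assay, so the step between them cannot be read. On these data alone, whether (ethoxycarbonyl)methoxy in place of trifluoromethyl changes the tolerated concentration at all stays open.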